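From 4-methylphenyl to 4-nitrophenyl on the shared core

The compounds below may be only part of what the source reports. "The series", "measured", "known", "first", "only" and "open" are said of these compounds alone.

In an ADME assay on Vero cells (Chlorocebus sabaeus) for cytotoxicity, read by MTT assay (on this read-out higher numbers stand for weaker inhibition and lower numbers for stronger inhibition), compound 1 (`C=CCOc1cc(OC)c(C(=O)/C=C/c2ccccc2Br)c(OCC=C)c1`) reads 13900 nM and compound 2 (`C=CCOc1cc(OC)c(C(=O)/C=C/c2ccccn2)c(OCC=C)c1`) reads 2800 nM while compound 3 (`C=CCOc1cc(OC)c(C(=O)/C=C/c2ccc(C)cc2)c(OCC=C)c1`) reads 211000 nM as the highest of the three numbers. Compound 4 (`C=CCOc1cc(OC)c(C(=O)/C=C/c2ccc([N+](=O)[O-])cc2)c(OCC=C)c1`) differs from compound 3 by nitro in place of methyl on an aromatic carbon as nitro in place of methyl on an aromatic carbon, para to a large group. Three measured changes of the aromatic group bear on this: a 5.0-fold lower number from compound 1 to compound 2 (0.70 log units; beyond the scatter) is modest while a 15-fold higher number from compound 1 to compound 3 (1.18 log units; beyond the scatter) and a 75-fold higher number from compound 2 to compound 3 (1.88 log units; beyond the scatter) are both large. Among the measured compounds shown here, no measured compound here carries nitro. Both other aromatic groups sit below compound 3, so the expected change is an 8.4-fold lower number from compound 3 to compound 4 (0.93 log units; beyond the scatter) in this series. Compound 4 is estimated at 25000 nM within a range of 4000 nM to 150000 nM for now.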

Compound 4, half-maximal inhibitory concentration: 12600 nM
The estimate for compound 4 lay 2.0-fold (0.30 log units) above the measured number; the measured number falls inside the stated range.
By their numbers in this assay, from the lowest: compound 2; then compounds 4 and 1 (each within the scatter of the next); then compound 3.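

In this assay, exchanging methyl for nitro on the aromatic carbon para to a large group is a large step (a 17-fold lower number from compound 3 to compound 4 (1.22 log units; beyond the scatter)), so this place responds strongly to the group it carries. The 4-nitrophenyl group is not separated from 2-bromophenyl (a 1.1-fold lower number from compound 1 to compound 4 (0.04 log units; within the scatter)), while pyridin-2-yl remains apart from it (a 4.5-fold higher number from compound 2 to compound 4 (0.65 log units; beyond the scatter)), which leaves 4-methylphenyl alone at the high end among these aromatic groups. Nothing measured here accounts for these steps.

Still open, as far as these compounds go, is how other groups in this place would read, such as an amine or a carboxylic acid para to a large group. Also open, from the compounds shown here alone, is whether the methyl step would keep its size with an ethyl or longer chain there.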